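Ester chain shortening in dihydropyrimidinone thiophene and furan analogues

A few compounds are considered here, and "the series" means these few. Any claim that something is new, unique, unknown or untested is made for them only; others in the source may bear on it.

Compound 1 `CCCOC(=O)C1=C(C)NC(=O)NC1c1cccs1`: 43%
Compound 2 `CC1=C(C(=O)OCC(C)C)C(c2cccs2)NC(=O)N1`: 25%
Compound 3 `CCC(CC)OC(=O)C1=C(C)NC(=O)NC1c1ccco1`: 2%

Of the compounds shown here, three have been measured in an assay on membranes from CHO cells for displacement of a labelled ligand from adenosine receptor A1 (Homo sapiens), read by scintillation counting, with a stated time of 60 min, tested at 1 uM; a higher number here means more inhibition at the concentration tested (going by the name of the read-out), a lower number less inhibition. Compound 1 `CCCOC(=O)C1=C(C)NC(=O)NC1c1cccs1` gives 43% in this assay, compound 2 `CC1=C(C(=O)OCC(C)C)C(c2cccs2)NC(=O)N1` gives 25%, and compound 3 `CCC(CC)OC(=O)C1=C(C)NC(=O)NC1c1ccco1` gives 2%, the lowest of the three. Compound 1 and compound 2 differ in one place (hydrogen in place of methyl on a saturated chain carbon bound to two saturated chain carbons), and that change gave a number 18 percentage points higher from compound 2 to compound 1 (beyond the scatter). The difference between the cores of compound 2 and compound 3 is not broken down here.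

Compound 4 `CCC(C)OC(=O)C1=C(C)NC(=O)NC1c1ccco1` has not yet been measured. It differs from compound 3 in one place (hydrogen in place of methyl on a saturated chain carbon, two bonds along the chain from an oxygen next to a carbonyl group). Within the data shown here, this is the same kind of change as the one from compound 2 to compound 1, but the place is not the same: in compound 2 the methyl leaves a saturated chain carbon bound to two saturated chain carbons, whereas in compound 3 it leaves a saturated chain carbon two bonds along the chain from an oxygen next to a carbonyl group. Because compound 2 to compound 1 gave a number 18 percentage points higher from compound 2 to compound 1 (beyond the scatter) while compound 3 starts at 2%, a step of a number 10 percentage points higher from compound 3 to compound 4 (within the scatter) is expected, the estimate being tempered by the different place and core. Compound 4 is therefore expected to give about 12%, most likely between 0% and 30%.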

Compound 4, a percentage reported as inhibition, at one concentration (the size of the read-out at that concentration, not a potency): 6%
The estimate for compound 4 lay 6 percentage points above the measured number, within the range that was stated.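

In this assay, the change from pentan-3-yl to sec-butyl, with hydrogen in place of methyl on the saturated chain carbon two bonds along the chain from an oxygen next to a carbonyl group, gave a number 4 percentage points higher from compound 3 to compound 4 (within the scatter). Set beside the earlier step, this one does not show that the change behaves differently on the two cores: the same change on two cores in this assay, a number 18 percentage points higher (beyond the scatter) from compound 2 to compound 1 and a number 4 percentage points higher (within the scatter) from compound 3 to compound 4, 14 percentage points apart, within the scatter of two such steps This does not show that the change carries over with the same size, since there are only two pairs, the change sits at a different place in each, and the step on the core of compound 3 is itself within the scatter, so a real gain there is neither shown nor ruled out.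

The compounds shown leave open whether the chain of compound 1 would give a similar number on the core of compound 3. They also leave open what a longer chain, or an amine or a carboxylic acid on the chain, would do in this series.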